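A Larger Ring on the Imine Nitrogen: Expected Binding

A few compounds are considered here, and "the series" means these few. Any claim that something is new, unique, unknown or untested is made for them only; others in the source may bear on it.

Of the compounds shown here, three built on one shared core have been measured in an assay on DDT1 cells (Cricetulus griseus) for binding affinity to adenosine receptor A1 (Homo sapiens), read by radioligand binding; a higher number here means a weaker inhibitor, a lower number a stronger inhibitor. Compound 1 `CCNC(=O)OC[C@H]1OC(n2cnc3c(NC4CCOC4)ncnc32)[C@H](O)[C@@H]1O` gives 167 nM in this assay. Compound 2 `CC(C)NC(=O)OC[C@H]1OC(n2cnc3c(NC4CCOC4)ncnc32)[C@H](O)[C@@H]1O` gives 78 nM in this assay. Compound 3 `CC(C)/N=C(\S)OC[C@H]1OC(n2cnc3c(NC4CCOC4)ncnc32)[C@H](O)[C@@H]1O` gives 36 nM in this assay, the lowest of the three numbers and therefore the strongest inhibitor of the set, since its steps to both others lie beyond the scatter. The measured steps are all modest: a 2.1-fold lower number from compound 1 to compound 2 (0.33 log units; beyond the scatter), a 2.2-fold lower number from compound 2 to compound 3 (0.34 log units; beyond the scatter), and a 4.6-fold lower number from compound 1 to compound 3 (0.67 log units; beyond the scatter).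

Compound 4 `O[C@@H]1[C@@H](CO/C(S)=N/C2CCCC2)OC(n2cnc3c(NC4CCOC4)ncnc32)[C@@H]1O` differs from compound 3 in one place: cyclopentyl in place of isopropyl on a double-bonded nitrogen. Going by the values given here, no measured step swaps these two groups, so the expectation rests on a loose parallel. Among the compounds with values here, the step of a 2.1-fold lower number from compound 1 to compound 2 (0.33 log units; beyond the scatter) is the only one where the group on that nitrogen grows, and there the number fell. A similar, modest fall is therefore expected for compound 4, giving a 1.8-fold lower number from compound 3 to compound 4 (0.26 log units; within the scatter). Compound 4 is estimated at 20 nM in this assay. For compound 4 the expected range runs from 7 nM to 60 nM.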

Compound 4, inhibition constant: 72 nM
Compound 4: middle estimate off by 3.6-fold (0.56 log units), on the low side, and the stated range ends below it.
By their numbers in this assay, from the lowest: compounds 3, 4 and 2 (each within the scatter of the next, the first and the last beyond it); then compound 1.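

In this assay, going by these compounds alone, the first ring at this position gives a 2.0-fold higher number from compound 3 to compound 4 (0.30 log units; within the scatter), so cyclopentyl and isopropyl on the double-bonded nitrogen cannot be told apart here, and the fall in the number seen when ethyl gave way to isopropyl on the amide-type nitrogen of the earlier compounds has no clear counterpart in this step. Set against the two compounds that carry a carbonyl, compound 4 shows a 1.1-fold lower number from compound 2 to compound 4 (0.03 log units; within the scatter), which leaves those two level, and a 2.3-fold lower number from compound 1 to compound 4 (0.37 log units; beyond the scatter), which keeps it a stronger inhibitor than compound 1, although each of these comparisons swaps a larger group and so does not isolate the ring. Nothing available explains how this position responds to the larger group.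

Going by these compounds, whether the double-bonded nitrogen would tolerate a smaller or larger ring remains open, and cyclobutyl, cyclohexyl or phenyl there would test this against compound 4. On these data alone, it is also open whether cyclopentyl on the amide-type nitrogen of the carbonyl compounds would match isopropyl there, as it does in the pair compared here.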